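The source may report more compounds than this note shows. Statements on the series, on what has been measured and on what is new or still open speak of the compounds shown alone.

Compound 1 `O=c1ccoc2cc(OCc3cn(Cc4cccc(Br)c4)nn3)ccc12` carries a bromophenyl group on a saturated chain carbon bound to an aromatic nitrogen. In a functional assay on MDA-MB-231 cells (Homo sapiens) for cytotoxicity, read by MTT assay, with a stated time of 48 h (on this read-out higher numbers stand for weaker inhibition and lower numbers for stronger inhibition), compound 1 gives only a limit, > 100000 nM. Compound 2 `O=c1ccoc2cc(OCc3cn(Cc4ccc(Br)cc4)nn3)ccc12` is the nearest measured neighbour. In this assay compound 2 also gives only a limit, > 100000 nM. The step that the two limits leave unreadable from compound 1 to compound 2 cannot be sized, since (the limit of > 100000 nM in this assay, at which 2 of the 2 values shown sit). Compound 3 `O=c1ccoc2cc(OCc3cn(Cc4ccccc4F)nn3)ccc12` carries the change (2-fluorophenyl in place of 3-bromophenyl on a saturated chain carbon bound to an aromatic nitrogen). Among the measured compounds shown here, no measured step with a readable size bears on this change; the only neighbouring step, from compound 1 to compound 2, is unreadable, so there is no basis for expecting a move beyond the scatter. For compound 3 the expected step is a step that the limit leaves unreadable from compound 1 to compound 3, which lies within the scatter. Compound 3 is expected to sit again at the limit of this assay, with an estimate of 200000 nM and a range from 50000 nM to 1000000 nM.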

Compound 3, half-maximal inhibitory concentration: 29800 nM
The estimate for compound 3 lay 6.7-fold (0.83 log units) above the measured number, and the stated range ends above it.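

Among the compounds shown here, compound 3 is the first compound to give a number rather than a limit, so in this assay the read-out does respond to change on a saturated chain carbon bound to an aromatic nitrogen. 2-Fluorophenyl in place of 3-bromophenyl gives an at least 3.3-fold lower number from compound 1 to compound 3 (0.52 log units; beyond the scatter), and 2-fluorophenyl in place of 4-bromophenyl gives an at least 3.3-fold lower number from compound 2 to compound 3 (0.52 log units; beyond the scatter). Both sizes are only lower bounds, and the step between the two bromophenyl compounds still cannot be read: the limit of > 100000 nM in this assay, at which 2 of the 3 values shown sit.

The compounds shown do not separate the swap of bromine for fluorine from the shift in where the halogen sits, since no two of them carry both halogens at one place. As far as these compounds go, how a 2-bromobenzyl group, a plain benzyl group or an amine on the phenyl ring would read remains open.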